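Chloro to bromo on the shared core

A few compounds are considered here, and "the series" means these few. Any claim that something is new, unique, unknown or untested is made for them only; others in the source may bear on it.

Compound 1 `O=C(c1cccnc1)c1cc(Cl)ccc1O` gives 24000 nM
Compound 2 `C=CCOc1ccc(Cl)cc1C(=O)c1cccnc1` gives 75000 nM
Compound 3 `O=C(c1cccnc1)c1cc(Br)ccc1O` has no value yet

In a functional assay on HeLa cells (Homo sapiens) for cytotoxicity, read by sulforhodamine B assay, with a stated time of 48 h (a lower number here means a stronger inhibitor, a higher number a weaker inhibitor), compound 1 (24000 nM) holds the lower of the two numbers, which makes it the stronger inhibitor of the pair. Within the data shown here, its only neighbour is compound 2 (75000 nM). Compound 3 differs from compound 1 by one swap (bromo in place of chloro on an aromatic carbon), bromo in place of chloro on an aromatic carbon. Among the measured compounds shown here, the single measured step (a 3.1-fold higher number from compound 1 to compound 2 (0.49 log units; beyond the scatter)) is modest, and it comes from allyl in place of hydrogen on an oxygen, a different change in a different place. For the measured compounds named here, it therefore says little about this swap, and no measured step covers a change of this kind. No shift beyond the scatter is expected in this assay, and no clear direction. The estimated step is small (a 1.1-fold lower number from compound 1 to compound 3 (0.04 log units; within the scatter)). Compound 3 is expected at about 22000 nM (estimated range 10000 nM to 45000 nM).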

Compound 3, half-maximal inhibitory concentration: 29000 nM
Compound 3: the middle estimate sits 1.3-fold (0.12 log units) below what was measured, within the range that was stated.
By their numbers in this assay, from the lowest: compounds 1 and 3 (each within the scatter of the next); then compound 2.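

In this assay, bromo in place of chloro on the aromatic carbon para to the hydroxy group gives a 1.2-fold higher number from compound 1 to compound 3 (0.08 log units; within the scatter), so exchanging one of these halogens for the other leaves the reading within the usual spread of repeat measurements. Among these compounds, the earlier pair spoke only to the oxygen, where allyl in place of hydrogen gave a 3.1-fold higher number from compound 1 to compound 2 (0.49 log units; beyond the scatter); this is the first measured information about the halogen position, and it shows that bromo and chloro there cannot be told apart in this test. No measurement shown explains why the two compounds read alike.

Chloro and bromo each add a single heavy atom, so the effect of an amine, a carboxylic acid or a longer chain at this position remains open. Also open, going by these compounds, is whether fluoro or plain hydrogen there would read the same, and whether the swap would behave alike with the allyl group of compound 2 on the oxygen.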